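Adding a fluorobenzoyl group to a thiourea series

A few compounds are considered here, and "the series" means these few. Any claim that something is new, unique, unknown or untested is made for them only; others in the source may bear on it.

Compound 1 `NC(=S)N1CCc2c(OCCCCCOc3ccc(Cl)cc3)cccc21` carries a hydrogen on its amide-type nitrogen. In an ADME assay on Huh-7 cells (Homo sapiens) for cytotoxicity (a higher number here means that more compound is tolerated, a lower number that less compound is tolerated), compound 1 gives only a limit, > 50000 nM, so no number is known for it. Compound 1 thus stands at the limit of > 50000 nM in this assay, at which 2 of the 3 values shown sit. Compound 2 `O=C(NC(=S)N1CCc2cc(OCc3ccccc3)ccc21)c1ccccc1` gives 45200 nM in this assay. Compound 3 `O=C(NC(=S)N1CCc2cccc(OCc3ccccc3)c21)c1ccccc1` gives a limit of > 50000 nM in this assay. The unmeasured compound 4 `O=C(NC(=S)N1CCc2c(OCCCCCOc3ccc(Cl)cc3)cccc21)c1ccc(F)cc1` differs from compound 1 by (4-fluorophenyl)carbonyl in place of hydrogen on an amide-type nitrogen. Among the measured compounds shown here, no pair of measured compounds shows this same change, so the step can only be expected, and compound 2 and compound 3, which also carry an acyl substituent, give values close to this limit. Compound 4 is expected to show no step beyond the scatter, an at least 1.1-fold lower number from compound 1 to compound 4 (0.04 log units; that floor lies within the scatter), and is estimated at 45000 nM, between 20000 nM and 100000 nM.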

Compound 4, half-maximal cytotoxic concentration: 31100 nM
For compound 4 the middle estimate is 1.4-fold (0.16 log units) above the measured one; the range from low to high includes it.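

In this assay, placing (4-fluorophenyl)carbonyl on the amide-type nitrogen gives an at least 1.6-fold lower number from compound 1 to compound 4 (0.20 log units; that floor lies within the scatter). With the chloro-substituted ether chain of compound 1 kept in place, this acyl group therefore yields a real number rather than a limit. The full size of the step stays unknown, because compound 1 gives only a limit: the limit of > 50000 nM in this assay, at which 2 of the 4 values shown sit.

Still open, going by these compounds, is whether an unsubstituted benzoyl group, without the fluorine, would give a similar number on this chain. An acetyl group on the same nitrogen would show whether the aromatic ring is needed at all.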